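This account rests on a few compounds, and the source may have more. Where it says the series, first, only, none or still open, it means among the compounds named here.

Working notes on the series. The shared core of compound 1 `CCCc1nc(-c2ccccc2)c(CNCCN2CCN(c3ccc(F)cc3)CC2)o1` is kept through all three measured compounds; only the aryl group on the amine nitrogen in the ring and the length of the linking chain vary. In an assay on HEK293 cells for inhibition of Voltage-dependent T-type calcium channel subunit alpha-1G (Homo sapiens), read by fluorescence, tested at 10 uM (on this read-out lower numbers stand for less inhibition and higher numbers for more inhibition at the one concentration tested (going by the name of the read-out)), compound 1 gives 54.1%. Compound 2 `CCCc1nc(-c2ccccc2)c(CNCCCN2CCN(c3cccc(C)c3C)CC2)o1` gives 55.2% and compound 3 `CCCc1nc(-c2ccccc2)c(CNCCCN2CCN(c3ccccc3F)CC2)o1` gives 54.4%. Compound 1 holds the smallest of the three numbers, but its gap to compound 3 and its gap to compound 2 both fall within the scatter, so the three compounds read alike. Among the measured compounds shown here, the only measured step that swaps the aryl group on the ring nitrogen is a number 0.8 percentage points lower from compound 2 to compound 3 (within the scatter), a change that did not move the number beyond the scatter.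

Compound 4 `CCCc1nc(-c2ccccc2)c(CNCCN2CCN(c3ccccn3)CC2)o1` is the next compound, and it differs from compound 1 by pyridin-2-yl in place of 4-fluorophenyl on an amine nitrogen in a ring. For the measured compounds named here, this touches the same place as the one measured step, which was flat. Going by the values given here, no measured step covers a ring nitrogen entering the aryl group, so the expectation rests on that flat step alone. The step from compound 1 is expected to be a number 2.1 percentage points lower from compound 1 to compound 4 (within the scatter), nothing beyond the scatter. Compound 4 is therefore estimated at 52%, with a range from 38% to 66%.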

Compound 4, a percentage reported as inhibition, at one concentration (the size of the read-out at that concentration, not a potency): 48.1%
Compound 4: middle estimate off by 3.9 percentage points, on the high side, and the stated range covers the measured number.
By their numbers in this assay, from the lowest: compounds 4, 1, 3 and 2 (each within the scatter of the next).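

In this assay, pyridin-2-yl in place of 4-fluorophenyl on the amine nitrogen in the ring gives a number 6 percentage points lower from compound 1 to compound 4 (within the scatter) and so leaves the number inside the scatter. The earlier step at this place exchanged one aromatic ring of carbon only for another, whereas this one brings in a ring nitrogen and a hydrogen-bond acceptor, and the reading of compound 4 still stays within the scatter of compound 1. No evidence is available that bears on this result or accounts for it.

From the compounds shown here alone, what remains open is whether a group of another kind on this ring nitrogen, such as cyclohexyl, benzyl or acetyl, would carry the number beyond the scatter. Also open, going by these compounds, is whether pyridin-2-yl gives a similar reading on the linking chain of compound 3, and whether an isomeric pyridin-3-yl or pyridin-4-yl, with its ring nitrogen placed differently, behaves like the pyridin-2-yl of compound 4 at this position.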